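The source may hold more compounds than are shown below. What is called first, only, known or untested is meant among the compounds shown, and "the series" means these compounds.

Compound 1, `Cc1ccc([C@@H](C)Oc2cc3onc(CCC(=O)O)c3cc2Cl)nc1`, was tested in an ADME assay on the whole organism (plasma, Rattus norvegicus, strain Han-Wistar) for protein binding, read by LC-MS, at a dose of 1 mg/kg by the intravenous route, where compound 1 gives 99.1%. Among the compounds with values here, of the two compounds measured so far, compound 1 has the lowest unbound fraction; the other measured compound, compound 2, `CCOc1cc2oc(=O)n(CCC(=O)O)c2cc1Cl`, gives 81.6% in this assay, a much higher unbound fraction than that of compound 1, well beyond the scatter. Compounds 1 and 2 differ in several places at once, so their gap cannot be tied to any single change.

Compound 3, `C[C@@H](Oc1cc2onc(CCC(=O)O)c2cc1Cl)c1ccccn1`, has not yet been measured. It differs from compound 1 in one place: hydrogen in place of methyl on an aromatic carbon. Within the data shown here, no measured pair here shows what this change does on its own, so the expectation rests on compound 1 alone. Removing one small group is expected to shift the bound share only a little, most likely toward a slightly higher unbound fraction. For compound 3, the step is expected to be a 1.7-fold higher unbound fraction from compound 1 to compound 3 (0.22 log units; within the scatter), within the scatter. Compound 3 is thus estimated to give 98.5% in this assay, with a likely range from 97% to 99.3%.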

Compound 3, plasma protein binding: 97.8%
Compound 3: the middle estimate sits 1.5-fold (0.17 log units) (unbound fraction) below what was measured; the measured number falls inside the stated range.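

Going from the 5-methylpyridin-2-yl group of compound 1 to the pyridin-2-yl group of compound 3 gives, in this assay, a 2.4-fold higher unbound fraction from compound 1 to compound 3 (0.39 log units; beyond the scatter) with only this one methyl gone from an aromatic carbon two atoms from the ring nitrogen. The step is modest, yet it lies beyond the usual scatter, which means that a very small edit at this position can be told apart from repeat-to-repeat noise. Within the data shown here, compounds 1 and 2 differ in several places at once, and this new pair is the first here that ties a shift in binding to a single change, although no measurement at hand says what lies behind the shift.

This position has so far been seen with only methyl and hydrogen, leaving open what a fluorine, a chlorine, a methoxy group or a longer chain such as ethyl would do at the same carbon. As far as these compounds go, it also remains open whether removing a methyl at this place would give a similar step on a different core, as a single pair cannot establish a general rule.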